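This account rests on a few compounds, and the source may have more. Where it says the series, first, only, none or still open, it means among the compounds named here.

Measured so far in a functional assay on MCF7 cells (Homo sapiens) for inhibition, read by MTT assay, with a stated time of 72 h; a higher number here means a weaker inhibitor, a lower number a stronger inhibitor:
- compound 1 `C=CCSc1nc2nc(C)cc(Nc3cc(-c4ccccc4)[nH]n3)n2n1`: > 50000 nM (a limit of the assay, not a number)
- compound 2 `Cc1cc(Nc2cc(-c3ccccc3)[nH]n2)n2nc(SCc3csc4ccccc34)nc2n1`: 3470 nM

Of these two results, only compound 2 has a true number, 3470 nM. Compound 1 gives only a limit: the limit of > 50000 nM in this assay, at which 1 of the 2 values shown sits. For the measured compounds named here, compound 2 therefore has no measured neighbour with an exact value to be ranked against, although the one step available is informative.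

Compound 3 `CCCSc1nc2nc(C)cc(Nc3cc(-c4ccccc4)[nH]n3)n2n1` has not yet been measured. It keeps the shared core of compound 2 and differs in one place: ethyl in place of 1-benzothiophen-3-yl on a saturated chain carbon bound to a sulfur. In words, ethyl replaces 1-benzothiophen-3-yl on a saturated chain carbon bound to a sulfur, so (1-benzothiophen-3-yl)methyl becomes propyl.

A single measured step bears on this change: an at least 14-fold lower number from compound 1 to compound 2 (1.15 log units; beyond the scatter). That large step, beyond the scatter, brought in the same 1-benzothiophen-3-yl that compound 3 loses, though the group it replaced was vinyl rather than ethyl. Resting on this one step, a similarly large move in the opposite direction, towards a weaker inhibitor, is expected in this assay. The expected change is a 13-fold higher number from compound 2 to compound 3 (1.11 log units; beyond the scatter). For compound 3 the estimated value is 45000 nM, with an expected range from 15000 nM to 120000 nM.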

Compound 3, half-maximal inhibitory concentration: > 50000 nM
Compound 3: no number, only a limit; the forecaster's own chance of this, stated with the estimate: 60%; at least 1.1-fold (0.04 log units) between middle value and limit.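

In this assay, replacing the 1-benzothiophen-3-yl with ethyl on the saturated chain carbon bound to a sulfur gives an at least 14-fold higher number from compound 2 to compound 3 (1.15 log units; beyond the scatter). The large gain seen for compound 2 therefore does not hold only against the vinyl end of compound 1. It appears against a saturated ethyl end as well, and among these three compounds a true number comes only with the 1-benzothiophen-3-yl group. Compound 1 and compound 3 both give only a limit, so no step between them can be read, and whether vinyl or ethyl is the better end stays unknown: the limit of > 50000 nM in this assay, at which 2 of the 3 values shown sit.

The step from compound 2 is also a minimum, so the true size of the loss is not known, and the shown compounds do not separate the two rings of the 1-benzothiophen-3-yl from each other. A plain phenyl group on the same carbon, or a longer chain such as hexyl in place of the propyl of compound 3, would show whether the fused pair of rings is needed or whether a smaller ring or simply more carbon atoms would give a measurable number.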